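The source may report more compounds than this note shows. Statements on the series, on what has been measured and on what is new or still open speak of the compounds shown alone.

Three compounds have been examined in an assay on isolated protein for inhibition of aldehyde dehydrogenase 1A1 (Homo sapiens), read by spectrophotometry, tested at 10 uM; on this read-out higher numbers stand for more inhibition at the one concentration tested (going by the name of the read-out) and lower numbers for less inhibition. Compound 1 `Cc1cccc(Cn2c(CN3CCN(C(=O)c4cccnc4)CC3)nc3ccccc32)c1` gives 24.5%, compound 2 `CC(C)CCn1c(OC2CCN(C(=O)c3ccco3)CC2)nc2ccccc21` gives 30.8%, and compound 3 `Cc1cccc(Cn2c(OC3CCN(C(=O)C4CC4)CC3)nc3ccccc32)c1` gives 80.6%. The number for compound 1 is the lowest of the three, although the numbers of compound 1 and compound 2 lie within the usual scatter of each other, so the two cannot be told apart on this read-out. Compound 3 stands well beyond the scatter above compound 1, but the two differ in more than one place, so no single change can be held responsible for that gap.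

Compound 4 `Cc1cccc(Cn2c(CN3CCN(C(=O)c4ccncc4)CC3)nc3ccccc32)c1` has not yet been measured. It differs from compound 1 only by pyridin-4-yl in place of pyridin-3-yl on a carbonyl carbon; the two have the same atoms, joined differently. Among the measured compounds shown here, none of the measured pairs isolates such an exchange, so there is nothing in the data to say how much it matters here. With no change in atom count, donors or acceptors, the step of a number 1.5 percentage points higher from compound 1 to compound 4 (within the scatter) is expected to be small, none beyond the scatter. Compound 4 is therefore estimated to give about 26%, with a range from 10% to 45%, and the measurement will show whether that holds.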

Compound 4, a percentage reported as inhibition, at one concentration (the size of the read-out at that concentration, not a potency): 20.6%
Compound 4: middle estimate off by 5.4 percentage points, on the high side, and the stated range covers the measured number.
By their numbers in this assay, from the lowest: compounds 4, 1 and 2 (each within the scatter of the next, the first and the last beyond it); then compound 3.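

Among the compounds shown here, the first pair in this set that differs in one place shows that, in this assay, putting pyridin-4-yl in place of pyridin-3-yl on a carbonyl carbon gives a number 3.9 percentage points lower from compound 1 to compound 4 (within the scatter). On this scaffold the two pyridine attachments therefore cannot be told apart, and the point at which the ring is joined to the carbonyl is not shown to matter for this read-out. Nothing measured on either group bears on this result, so no account can be given of why the two read alike.

The compounds shown leave open whether any other group on this carbonyl would read differently, for instance pyridin-2-yl, a plain phenyl ring or a simple alkyl chain, since only these two pyridine attachments have been compared directly. Compound 3 carries a different group on its carbonyl and also differs elsewhere, so how much of its distance from this pair belongs to the carbonyl group and how much to its other differences remains unsettled.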